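This account rests on a few compounds, and the source may have more. Where it says the series, first, only, none or still open, it means among the compounds named here.

Compound 1 `COc1cc(-c2nnc(SCC(=O)Nc3ccc(/C(C)=N/O)cc3)n2-c2ccccc2)cc(OC)c1OC` carries phenyl on the aromatic nitrogen, compound 2 `CCn1c(SCC(=O)Nc2ccc(/C(C)=N/O)cc2)nnc1-c1cc(OC)c(OC)c(OC)c1` carries ethyl there, and compound 3 `C=CCn1c(SCC(=O)Nc2ccc(/C(C)=N/O)cc2)nnc1-c1ccc(OC)c(OC)c1` differs from both in the group on that nitrogen and in its methoxy pattern. In a functional assay on the whole organism (strain albino) for inhibition, with Rattus norvegicus as the target, read by paw edema, with stated times of 30 min and 4 h, at a dose of 0.28 mmol/kg by the oral route (on this read-out higher numbers stand for more inhibition at the one dose given (going by the name of the read-out) and lower numbers for less inhibition), compound 1 gives 75%, compound 2 gives 70%, and compound 3 gives 79%. Among the measured compounds shown here, the only measured step lies within the scatter: a number 5 percentage points lower from compound 1 to compound 2 (within the scatter). Compound 3 has the highest of the three numbers, yet its gaps to compound 1 and to compound 2 are both within the scatter, so no order among the three can be claimed.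

Compound 4 `C=CCn1c(SCC(=O)Nc2ccc(/C(C)=N/O)cc2)nnc1-c1cc(OC)c(OC)c(OC)c1` differs from compound 3 by methoxy in place of hydrogen on an aromatic carbon. For the measured compounds named here, no measured step bears directly on this change; the one step on record concerns the group on the aromatic nitrogen and was within the scatter. Compound 1 and compound 2, which carry methoxy at this position, give numbers within the scatter of compound 3. The change is therefore expected to give no step beyond the scatter, a number 3 percentage points lower from compound 3 to compound 4 (within the scatter). For compound 4 the estimate is 76%, with a range from 66% to 86%.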

Compound 4, a percentage reported as inhibition, in the whole organism at one dose (the size of the read-out at that dose, not a potency): 72%
Estimate against measurement, compound 4: 4 percentage points above; the measured number falls inside the stated range.
By their numbers in this assay, from the lowest: compounds 2, 4, 1 and 3 (each within the scatter of the next).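

Methoxy in place of hydrogen on an aromatic carbon, ortho to a methoxy group, gives a number 7 percentage points lower from compound 3 to compound 4 (within the scatter) in this assay and so gives this position its first direct step, which shows no change that can be read. On the aromatic nitrogen, allyl in place of phenyl gives a number 3 percentage points lower from compound 1 to compound 4 (within the scatter) and vinyl in place of methyl on the saturated chain carbon gives a number 2 percentage points higher from compound 2 to compound 4 (within the scatter) and, with the earlier ethyl step, phenyl, ethyl and allyl cannot be told apart there. No supporting data bear on these results.

As far as these compounds go, whether an amine or a hydroxyl group in place of this methoxy would give a step beyond the scatter remains open. The same holds for a longer chain or a carboxylic acid on the aromatic nitrogen.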